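The source may report more compounds than this note shows. Statements on the series, on what has been measured and on what is new or still open speak of the compounds shown alone.

For the measured compounds named here, the two compounds measured so far share one core and differ only in a halogenated phenyl ring on a saturated ring carbon. Going by the values given here, compound 1 `Cn1ncc(Cl)c1-c1cc(C(=O)N[C@@H]2CN[C@H](CC(O)CO)C[C@H]2c2ccc(F)c(F)c2)oc1Cl` was tested in an assay for inhibition of RAC-alpha serine/threonine-protein kinase (Homo sapiens), read by HTRF, with a stated time of 1 h (a higher number here means a weaker inhibitor, a lower number a stronger inhibitor), and gives 3.31 nM; its only neighbour, compound 2 `Cn1ncc(Cl)c1-c1cc(C(=O)N[C@@H]2CN[C@H](CC(O)CO)C[C@H]2c2ccc(Cl)c(Cl)c2)oc1Cl`, gives 3.79 nM in this assay. The step of a 1.1-fold higher number from compound 1 to compound 2 (0.06 log units; within the scatter) puts 3,4-dichlorophenyl in place of 3,4-difluorophenyl and falls within the scatter, so the two stand level.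

Compound 3 `CNC(=O)C[C@@H]1C[C@@H](c2ccc(F)c(F)c2)[C@H](NC(=O)c2cc(-c3c(Cl)cnn3C)c(Cl)o2)CN1` has not yet been measured. It differs from compound 1 elsewhere: methylcarbamoyl in place of 1,2-dihydroxyethyl on a saturated chain carbon bound to a saturated ring carbon; the same difference, cut one bond further out, reads 2,3-dihydroxypropyl to (methylcarbamoyl)methyl. Among the compounds with values here, no measured step touches this side chain, and the single step measured concerns the phenyl ring alone, so it offers no guide to the change in hand. In the absence of any such guide, the expected step in this assay is a 1.5-fold higher number from compound 1 to compound 3 (0.18 log units; within the scatter), a modest weakening at most and quite possibly none beyond the scatter. For compound 3 the estimate in this assay is 5 nM, with a range from 1.5 nM to 20 nM.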

Compound 3, half-maximal inhibitory concentration: 1.37 nM
Compound 3: the middle estimate sits 3.6-fold (0.56 log units) above what was measured; measured number below the stated range.
By their numbers in this assay, from the lowest: compound 3; then compounds 1 and 2 (each within the scatter of the next).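

Replacing 1,2-dihydroxyethyl with methylcarbamoyl on a saturated chain carbon bound to a saturated ring carbon gives, in this assay, a 2.4-fold lower number from compound 1 to compound 3 (0.38 log units; beyond the scatter). For the compounds shown here, this is the first measured change at this side chain, and it shows that the position responds to what it carries, whereas the only earlier step, on the phenyl ring, was a 1.1-fold higher number from compound 1 to compound 2 (0.06 log units; within the scatter). The new group has the same count of 4 heavy atoms as the old one but holds 1 hydrogen-bond donor and 1 hydrogen-bond acceptor against 2 of each, so in this pair the diol is not required for a low number, although no measurement here explains the modest gain.

The compounds shown do not separate the contributions of the carbonyl and the methyl group within methylcarbamoyl, and they leave open how a plain carbamoyl, a dimethylcarbamoyl, a carboxylic acid, an amine or a longer chain would behave at this position. They also leave open whether the same side-chain change would give a similar step on the 3,4-dichlorophenyl compound, compound 2.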